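Methylsulfonyl for dichlorobenzoyl on the ring nitrogen

The compounds below may be only part of what the source reports. "The series", "measured", "known", "first", "only" and "open" are said of these compounds alone.

Three compounds share one core. Compound 1 `CN(C)c1ccc(C2CC(c3ccc(-n4cncn4)cc3)=NN2)cc1`, compound 2 `CN(C)c1ccc(C2CC(c3ccc(-n4cncn4)cc3)=NN2C(=O)CCCl)cc1` and compound 3 `CN(C)c1ccc(C2CC(c3ccc(-n4cncn4)cc3)=NN2C(=O)c2cc(Cl)cc(Cl)c2)cc1` were tested in a functional assay on NCI-H1975 cells (Homo sapiens) for inhibition, read by sulforhodamine B assay, tested at 10 uM; on this read-out higher numbers stand for more inhibition at the one concentration tested (going by the name of the read-out) and lower numbers for less inhibition. Compound 1 gives -3.3%, compound 2 gives -0.7% and compound 3 gives 8.4%. Compound 3 thus stands highest of the three: a number 11.7 percentage points higher from compound 1 to compound 3 (beyond the scatter), whereas a number 9.1 percentage points higher from compound 2 to compound 3 (within the scatter) and a number 2.6 percentage points higher from compound 1 to compound 2 (within the scatter).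

Compound 4 `CN(C)c1ccc(C2CC(c3ccc(-n4cncn4)cc3)=NN2S(C)(=O)=O)cc1` is not yet measured. It differs from compound 3 in one place: methylsulfonyl in place of (3,5-dichlorophenyl)carbonyl on an amine nitrogen in a ring. For the measured compounds named here, the steps that bear on this change are the gain from compound 1 to compound 3, which was beyond the scatter, and the gain from compound 2 to compound 3, which was not; the entering group, like the (2-chloroethyl)carbonyl of compound 2, has no ring. The numbers for compound 2 and compound 1 suggest that removing the (3,5-dichlorophenyl)carbonyl loses most of the gain, so the step to compound 4 is expected to be downward, a number 7.4 percentage points lower from compound 3 to compound 4 (within the scatter), though within the scatter. In this assay compound 4 is therefore expected to give about 1%, between -9% and 11%.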

Compound 4, a percentage reported as inhibition, at one concentration (the size of the read-out at that concentration, not a potency): -3.1%
Compound 4: the middle estimate sits 4.1 percentage points above what was measured; low and high end bracket the measured number.
By their numbers in this assay, from the lowest: compounds 1, 4, 2 and 3 (each within the scatter of the next, the first and the last beyond it).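

In this assay, methylsulfonyl in place of (3,5-dichlorophenyl)carbonyl on the ring nitrogen gives a number 11.5 percentage points lower from compound 3 to compound 4 (beyond the scatter), whereas methylsulfonyl in place of hydrogen gives a number 0.2 percentage points higher from compound 1 to compound 4 (within the scatter) and in place of (2-chloroethyl)carbonyl gives a number 2.4 percentage points lower from compound 2 to compound 4 (within the scatter). A sulfonyl group without a ring at this position thus cannot be told apart from hydrogen or from (2-chloroethyl)carbonyl, while the (3,5-dichlorophenyl)carbonyl of compound 3 stands clear of both hydrogen and methylsulfonyl, though not of the (2-chloroethyl)carbonyl of compound 2. No measurement available here explains this difference.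

From the compounds shown here alone, it remains open whether the small gain of compound 3 rests on the carbonyl, the phenyl ring or the two chlorines. An unsubstituted benzoyl and a phenylsulfonyl on the same nitrogen would separate these parts.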